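Swapping propargyl for (3-methoxyphenyl)carbonyl on the shared core

This account rests on a few compounds, and the source may have more. Where it says the series, first, only, none or still open, it means among the compounds named here.

Compound 1 `COc1cc(OC)c(-c2coc3cc(OCC=C(C)C)ccc3c2=O)cc1OC` gives 3500 nM 
Compound 2 `C#CCOc1ccc2c(=O)c(-c3cc(OC)c(OC)cc3OC)coc2c1` gives 6450 nM 

Among the compounds with values here, in a functional assay on U-251 cells (Homo sapiens) for antiproliferative activity, read by MTT assay, with a stated time of 24 h (a lower number here means a stronger inhibitor, a higher number a weaker inhibitor), only these two compounds have numbers so far. Within the data shown here, compound 2 at 6450 nM stands level with compound 1 within the scatter, and the single measured step is a 1.8-fold higher number from compound 1 to compound 2 (0.27 log units; within the scatter) as the only guide. Compound 3 `COc1cccc(C(=O)Oc2ccc3c(=O)c(-c4cc(OC)c(OC)cc4OC)coc3c2)c1` has no number yet. The change from compound 2 to compound 3 is (3-methoxyphenyl)carbonyl in place of propargyl on an oxygen on an aromatic ring and puts (3-methoxyphenyl)carbonyl in place of propargyl on an oxygen on an aromatic ring. Among the measured compounds shown here, the measured step also changes the group on that oxygen, but no measured compound carries a carbonyl or a ring there, so it bears on this change only loosely. Going by these compounds, no shift beyond the scatter is therefore expected in this assay and the direction stays open. The expected step is a 1.4-fold lower number from compound 2 to compound 3 (0.16 log units; within the scatter) and it remains a rough estimate. For compound 3 the estimated value is 4500 nM with 1500 nM to 14000 nM as the expected range.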

Compound 3, half-maximal inhibitory concentration: > 10000 nM
Compound 3 gave a limit, no number (the forecaster's own chance of this, stated with the estimate: 7%); at least 2.2-fold (0.34 log units) between middle value and limit.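

In this assay, compound 3 gives > 10000 nM, which is a limit and not a number. Putting (3-methoxyphenyl)carbonyl in place of 3-methylbut-2-en-1-yl on the oxygen on an aromatic ring gives an at least 2.8-fold higher number from compound 1 to compound 3 (0.45 log units; beyond the scatter), a step beyond the scatter that the earlier pair did not give, so the read-out at this position does respond to the group it carries. Going by these compounds, the same group in place of propargyl gives an at least 1.5-fold higher number from compound 2 to compound 3 (0.19 log units; that floor lies within the scatter), so this floor alone does not separate the two compounds, and the true size of the step remains unknown.

What the compounds shown leave open is whether the carbonyl or the aromatic ring of the entering group goes with the higher number. On these data alone, how a benzyl group or a longer saturated chain on that oxygen would read also stays open.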